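Branching the ring-nitrogen chain: compound 3 to compound 4

The compounds below may be only part of what the source reports. "The series", "measured", "known", "first", "only" and "open" are said of these compounds alone.

In a functional assay for antagonist activity at corticotropin-releasing factor receptor 1 (Rattus norvegicus) (a lower number here means a stronger inhibitor, a higher number a weaker inhibitor), compound 1 `CC[C@H](C1CC1)n1c(=O)c(C)nc2c(-c3cc(F)c(OC)cc3Cl)ccnc21` gives 1.7 nM, compound 2 `CCC(C1CC1)n1c(=O)c(C)nc2c(-c3cc(Cl)c(OC(F)F)cc3C)ccnc21` gives 9.7 nM, and compound 3 `CCCC(C)n1c(=O)c(C)nc2c(-c3ccc(Cl)cc3Cl)ccnc21` gives 62 nM. Compound 3 thus carries the highest number of the three; its gaps to compound 2 and to compound 1 both lie beyond the scatter, so it is the weakest inhibitor in this set. Compound 4 `Cc1nc2c(-c3ccc(Cl)cc3Cl)ccnc2n(C(C)C(C)C)c1=O` is not yet measured. It differs from compound 3 only in the chain on the ring nitrogen: isopropyl in place of propyl on a saturated chain carbon bound to an aromatic nitrogen and a saturated chain carbon. Within the data shown here, no measured pair isolates this change; compound 1 and compound 2 carry a different chain but also a different aryl group, so no direction can be read from them. A small step toward a lower number is expected, a 1.6-fold lower number from compound 3 to compound 4 (0.19 log units; within the scatter). Compound 4 is estimated at 40 nM, within 12 nM to 130 nM.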

Compound 4, half-maximal inhibitory concentration: 380 nM
For compound 4 the middle estimate is 9.5-fold (0.98 log units) below the measured one; the measured number lies above the stated range.
By their numbers in this assay, from the lowest: compound 1; then compound 2; then compound 3; then compound 4.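

This first matched pair shows that this assay is sensitive to the arrangement of the chain on the ring nitrogen alone: with the same atoms, isopropyl in place of propyl gives a 6.1-fold higher number from compound 3 to compound 4 (0.79 log units; beyond the scatter). Read one bond further out, the change is 1-methylbutyl to 1,2-dimethylpropyl, so the shape of this chain matters even on an unchanged core and aryl group. No available data account for this step. On these data alone, whether the step carries over to the aryl groups of compound 1 and compound 2 remains open, as does how a cyclopentyl group or a longer chain would compare at this position.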